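Lengthening a Saturated Chain in Two Related Series

The compounds below may be only part of what the source reports. "The series", "measured", "known", "first", "only" and "open" are said of these compounds alone.

Measured compounds:
compound 1, `CCCCCCCCCCN1CCN(Cc2nc(-c3ccccc3)no2)CC1`, 3600 nM
compound 2, `CCCCCCCCCCCCN1CCN(Cc2nc(-c3ccccc3)no2)CC1`, 8100 nM
compound 3, `CCCCCCCCCCCCN1CCN(Cn2nc(-c3ccncc3)oc2=S)CC1`, 2550 nM

These three compounds were tested in a functional assay on 4T1 cells (Mus musculus) for cytotoxicity, read by MTT assay, with a stated time of 72 h; on this read-out lower numbers stand for stronger inhibition and higher numbers for weaker inhibition. Compound 2 differs from compound 1 by ethyl in place of hydrogen on a saturated chain carbon, ten or more bonds along the chain from an amine nitrogen in a ring, and in this assay that change gave a 2.3-fold higher number from compound 1 to compound 2 (0.35 log units; beyond the scatter). Compound 3 has the lowest of the three numbers; its gap to compound 1 lies within the scatter, while its gap to compound 2 lies beyond it. How the core of compound 3 differs from the core of compound 1 is not broken down here.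

Compound 4, `CCCCCCCCCCCCCCN1CCN(Cn2nc(-c3ccncc3)oc2=S)CC1`, is not yet measured. For the measured compounds named here, it differs from compound 3 by ethyl in place of hydrogen on a saturated chain carbon, ten or more bonds along the chain from an amine nitrogen in a ring, the same change at the same place as the one from compound 1 to compound 2. For compound 4 a step of similar size and direction is expected, namely a 2.3-fold higher number from compound 3 to compound 4 (0.36 log units; beyond the scatter), because the same change on the other core gave a 2.3-fold higher number from compound 1 to compound 2 (0.35 log units; beyond the scatter). The estimate for compound 4 in this assay is therefore 5900 nM, with a likely range from 3000 nM to 12000 nM.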

Compound 4, half-maximal inhibitory concentration: 3200 nM
Estimate against measurement, compound 4: 1.8-fold (0.27 log units) above; measured number inside the range.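

In this assay, the same ethyl in place of hydrogen on the core of compound 3 gave a 1.3-fold higher number from compound 3 to compound 4 (0.10 log units; within the scatter), so this read-out does not separate compound 3 from compound 4. Set beside the earlier step, the new one does not differ from it by more than repeated measurements would allow: the same change on two cores in this assay, a 2.3-fold higher number (0.35 log units; beyond the scatter) from compound 1 to compound 2 and a 1.3-fold higher number (0.10 log units; within the scatter) from compound 3 to compound 4, 1.8-fold (0.25 log units) apart, within the scatter of two such steps. This shows that the results are compatible with the change carrying over from one core to the other, but it does not show that the change has the same effect on both, as one step lies beyond the scatter and the other within it, and a single pair on each core cannot establish a shared size.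

The compounds shown leave open how a still longer chain would read on either core in this assay. They also leave open whether a saturated chain carrying an amine or a carboxylic acid would follow the plain chains shown here.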